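This account rests on a few compounds, and the source may have more. Where it says the series, first, only, none or still open, it means among the compounds named here.

Measured in a functional assay on MIA PaCa-2 cells (Homo sapiens) for antiproliferative activity, read by MTT assay, with a stated time of 72 h; a higher number here means a weaker inhibitor, a lower number a stronger inhibitor:
- compound 1 `O=C1O/C(=C\Cn2cnc3c(F)nc(F)c(Cl)c32)C(OCc2ccccc2)=C1OCc1ccccc1`: 78000 nM
- compound 2 `O=C1NC(O)(CCn2cnc3cc[nH]c3c2=O)C(OCc2ccccc2)=C1OCc1ccccc1`: 36600 nM

Of these two, compound 2 gives the lower number, 36600 nM, and its gap to compound 1 lies beyond the scatter. Compound 3 `O=C1NC(O)(CCn2cnc3ccnc(Cl)c32)C(OCc2ccccc2)=C1OCc1ccccc1` keeps the shared core but carries a different group on the saturated chain: a group of 10 heavy atoms (6 carbon, 3 nitrogen, 1 chlorine; one five-membered aromatic ring with 2 hetero atoms, one six-membered aromatic ring with 1 hetero atom) in place of a group of 10 heavy atoms (6 carbon, 3 nitrogen, 1 oxygen; one five-membered aromatic ring with 1 hetero atom, one six-membered aromatic ring with 2 hetero atoms), on a saturated chain carbon, two bonds along the chain from a saturated ring carbon. Among the compounds with values here, the series has no measured step for this exchange, so the direction is uncertain. Expected in this assay: a 1.5-fold lower number from compound 2 to compound 3 (0.17 log units; within the scatter), a modest move towards a lower number. The estimate for compound 3 is 25000 nM, with an expected range of 8000 nM to 70000 nM.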

Compound 3, half-maximal inhibitory concentration: 60000 nM
The estimate for compound 3 lay 2.4-fold (0.38 log units) below the measured number, within the range that was stated.
By their numbers in this assay, from the lowest: compounds 2, 3 and 1 (each within the scatter of the next, the first and the last beyond it).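

In this assay, replacing the group with 1 hydrogen-bond donor by the chlorine-bearing group with 0 hydrogen-bond donors, on a saturated chain carbon, gives a 1.6-fold higher number from compound 2 to compound 3 (0.21 log units; within the scatter). This first step at this position therefore shows no change beyond the scatter, even though the ring hetero atom counts shift, the double bond outside aromatic rings is lost and chlorine enters. No measured property bears on this result. A single exchange cannot show how far the position tolerates change. On these data alone, whether an amine or a carboxylic acid in place of the chlorine, or a longer chain, would move the number beyond the scatter remains open.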